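Phenyl for trifluoromethyl in the growth inhibition series

The compounds below may be only part of what the source reports. "The series", "measured", "known", "first", "only" and "open" are said of these compounds alone.

- compound 1 `COc1ccc(-c2nc3sc(-c4ccccc4)cn3n2)cc1` gives 28% here
- compound 2 `C/C(=N/O)c1ccc(NC(=O)Cn2nc(C(F)(F)F)nc2N)cc1` gives 4.46% here
- compound 3 `COc1cc(-c2nc(N)n(CC(=O)Nc3ccc(/C(C)=N\O)cc3)n2)cc(OC)c1OC` gives 4.21% here

All three values come from a functional assay on NCI-H23 cells (Homo sapiens) for inhibition, read by sulforhodamine B assay, with a stated time of 48 h, tested at 10 uM (a lower number here means less inhibition of growth, a higher number more inhibition of growth at the concentration tested), and form a small set. Compound 2 at 4.46% stands within the scatter of compound 3 at 4.21% on this read-out. Compound 1 gives 28% on the same read-out, and its gap to compound 2 lies beyond the scatter.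

The next compound is compound 4 `C/C(=N/O)c1ccc(NC(=O)Cn2nc(-c3ccccc3)nc2N)cc1` which has phenyl in place of trifluoromethyl on an aromatic carbon and otherwise matches compound 2. For the measured compounds named here, no measured pair isolates this change, so the expectation rests on indirect evidence. Compound 3 also carries a six-membered aromatic ring on that carbon, with further groups on it, and its 4.21% lies within the scatter of compound 2. Compound 1 differs too widely from compound 2 to guide this step.

The expected change is a number 2.5 percentage points higher from compound 2 to compound 4 (within the scatter) in this assay with a slight upward lean and no shift beyond the scatter. For compound 4 the estimated value is 7% with an expected range from -3% to 20% for now.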

Compound 4, percent growth inhibition at one concentration: 3.98%
Estimate against measurement, compound 4: 3 percentage points above, within the range that was stated.
By their numbers in this assay, from the lowest: compounds 4, 3 and 2 (each within the scatter of the next); then compound 1.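

In this assay, for the compounds shown here, this pair gives the first direct reading of phenyl in place of trifluoromethyl on an aromatic carbon, here the carbon between two ring nitrogen atoms: a number 0.5 percentage points lower from compound 2 to compound 4 (within the scatter). At this single concentration, the read-out does not separate the one-ring phenyl, with 6 heavy atoms, from the ring-free trifluoromethyl, with 4 heavy atoms, so this exchange gives no measurable handle on growth inhibition at this position. The compounds shown offer no independent measurement that could explain this lack of separation.

As far as these compounds go, whether any group on this carbon can move the number beyond the scatter remains open, for example an amine, a carboxylic acid or a longer alkyl chain. Going by these compounds alone, it is also open whether the same lack of separation would hold with a hydroxyl group in place of the amino group on the ring, since the present pair tests only one exchange against one fixed set of remaining groups.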